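Naphthyl in Place of Fluorophenyl: An Expected Small Step

The source may report more compounds than this note shows. Statements on the series, on what has been measured and on what is new or still open speak of the compounds shown alone.

Of the compounds shown here, two built on one shared core have been tested in a functional assay on HT-29 cells (Homo sapiens) for cytotoxicity, read by sulforhodamine B assay; on this read-out lower numbers stand for stronger inhibition and higher numbers for weaker inhibition. Compound 1, with structure `C=C1[C@@H](C/C=C2/C(=O)OC[C@H]2OC(C)=O)[C@]2(C)CC[C@@H](OC(C)=O)[C@@](C)(CO[Si](C)(C)C(C)(C)C)[C@H]2C[C@@H]1O`, gives 9310 nM. Compound 2, with structure `C=C1[C@@H](OC(C)=O)C[C@@H]2[C@](C)(CO[Si](C)(C)C(C)(C)C)[C@H](OC(C)=O)CC[C@@]2(C)[C@@H]1C[C@@H](Nc1ccccc1F)C1=CCOC1=O`, gives 3710 nM. Of these two numbers, compound 2 has the lower one, and its gap to compound 1 lies beyond the usual scatter, so compound 2 is the stronger inhibitor of the pair. The two structures differ in several places, so the numbers alone say nothing about any single change.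

Compound 3, with structure `C=C1[C@@H](OC(C)=O)C[C@@H]2[C@](C)(CO[Si](C)(C)C(C)(C)C)[C@H](OC(C)=O)CC[C@@]2(C)[C@@H]1C[C@@H](Nc1cccc2ccccc12)C1=CCOC1=O`, is not yet measured. It differs from compound 2 in one place only: naphthalen-1-yl in place of 2-fluorophenyl on an amine nitrogen. Among the compounds with values here, no measured pair shows a change of this kind, so there is no measured guide for it. The step of a 1.2-fold lower number from compound 2 to compound 3 (0.06 log units; within the scatter) is expected to stay within the scatter, in no clear direction. Compound 3 is therefore expected to give about 3200 nM, with a range from 1200 nM to 8500 nM.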

Compound 3, half-maximal inhibitory concentration: 15000 nM
The estimate for compound 3 lay 4.7-fold (0.67 log units) below the measured number, and the stated range ends below it.
By their numbers in this assay, from the lowest: compound 2; then compounds 1 and 3 (each within the scatter of the next).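

On the amine nitrogen of the shared core, the choice of aromatic group clearly matters: in this assay, naphthalen-1-yl in place of 2-fluorophenyl brings a 4.0-fold higher number from compound 2 to compound 3 (0.61 log units; beyond the scatter) and so weaker inhibition. This is the only pair shown that differs in one place, so it is the only comparison that ties a change in the number to a single position. Nothing shown explains this loss, and this pair cannot tell whether the second aromatic ring or the absent fluorine accounts for it.

A plain phenyl on the same nitrogen would help separate those two differences, since it has one ring, like 2-fluorophenyl, but no fluorine. On these data alone, how a saturated group such as cyclohexyl would compare at this nitrogen also remains open.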